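Amide-nitrogen aryl swap on the shared thiazolidinedione core

The source may hold more compounds than are shown below. What is called first, only, known or untested is meant among the compounds shown, and "the series" means these compounds.

In an assay on isolated protein for inhibition of histone deacetylase 4 (Homo sapiens), with a stated time of 1 h (on this read-out higher numbers stand for weaker inhibition and lower numbers for stronger inhibition), compound 2 `O=C(COc1ccc2cc(/C=C3/SC(=O)NC3=O)ccc2c1)Nc1ccccc1` gives 2100 nM, the lowest of the two numbers in hand. Compound 1 `CCOc1ccc2nc(NC(=O)COc3ccc4cc(/C=C5/SC(=O)NC5=O)ccc4c3)sc2c1` gives 3600 nM in this assay, and the two values sit within the scatter of each other, so neither is called the stronger. For the measured compounds named here, compound 3 `Cc1cccc2sc(NC(=O)COc3ccc4cc(/C=C5/SC(=O)NC5=O)ccc4c3)nc12` differs from compound 2 by 4-methyl-1,3-benzothiazol-2-yl in place of phenyl on an amide-type nitrogen; no measured pair covers this step. Compound 1 already carries a bicyclic amide substituent and reads 3600 nM, so for compound 3 a step no larger than the scatter is expected in this assay. The estimate for compound 3 is 2800 nM, from 1200 nM to 7000 nM, which means a 1.3-fold higher number from compound 2 to compound 3 (0.12 log units; within the scatter).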

Compound 3, half-maximal inhibitory concentration: 1200 nM
Compound 3: middle estimate off by 2.3-fold (0.37 log units), on the high side; the range from low to high includes it.
By their numbers in this assay, from the lowest: compounds 3, 2 and 1 (each within the scatter of the next, the first and the last beyond it).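

In this assay, 4-methyl-1,3-benzothiazol-2-yl in place of phenyl on an amide-type nitrogen gives a 1.8-fold lower number from compound 2 to compound 3 (0.24 log units; within the scatter), so this step stays within the scatter. This position therefore accepts the change from 6 to 10 heavy atoms, and from 0 to 2 hydrogen-bond acceptors, without a step beyond the scatter. No measurement in hand gives a reason for this result.

Open, as far as these compounds go, is whether any group on this nitrogen moves the number beyond the scatter. A carboxylic acid on the phenyl ring or a cyclohexyl group in its place would test this.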